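This account rests on a few compounds, and the source may have more. Where it says the series, first, only, none or still open, it means among the compounds named here.

Measured so far:
compound 1 `CN(C)c1ccc(C2CC(c3ccc(-n4ccnc4)cc3)=NN2)cc1` — -20.9%
compound 2 `CN1CCN(c2ccc(C3=NN(C(=O)c4ccc(C(F)(F)F)cc4)C(c4ccc(N(C)C)cc4)C3)cc2)CC1` — 84.1%

In a functional assay on HCC1806 cells (Homo sapiens) for inhibition, read by sulforhodamine B assay, tested at 10 uM (on this read-out lower numbers stand for less inhibition and higher numbers for more inhibition at the one concentration tested (going by the name of the read-out)), compound 1 gives -20.9%, the lowest of the two numbers recorded. The nearest measured neighbour, compound 2, gives 84.1%, a gap that lies beyond the usual scatter. Among the compounds with values here, compound 2 differs from compound 1 in several places at once, so no single step connects the two and their values say only that a substituted ring nitrogen is present in the more inhibiting compound.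

Compound 3 `CN(C)c1ccc(C2CC(c3ccc(-n4ccnc4)cc3)=NN2S(=O)(=O)c2ccc(C#N)cc2)cc1` follows from compound 1 by one change: (4-cyanophenyl)sulfonyl in place of hydrogen on an amine nitrogen in a ring

With only compound 1 and compound 2 to go by, the step from compound 1 to compound 3 is expected to be an increase in this assay, of a size beyond the scatter, a number 65.9 percentage points higher from compound 1 to compound 3 (beyond the scatter). Compound 3 is accordingly estimated at 45%, with a range from 5% to 85%.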

Compound 3, a percentage reported as inhibition, at one concentration (the size of the read-out at that concentration, not a potency): 4.7%
Compound 3: middle estimate off by 40.3 percentage points, on the high side; the whole stated range lies above it.
By their numbers in this assay, from the lowest: compound 1; then compound 3; then compound 2.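

In this assay, the ring amine nitrogen proves to be a position where a single change moves the read-out: (4-cyanophenyl)sulfonyl in place of hydrogen gives a number 25.6 percentage points higher from compound 1 to compound 3 (beyond the scatter), a modest step that lies beyond the scatter. Within the data shown here, this is the first one-place comparison, and it shows that substitution on this nitrogen alone, with the rest of the core of compound 1 unchanged, is enough to raise the inhibition. Nothing available on these compounds accounts for the size of the step.

On these data alone, it remains open whether the sulfonyl link or the 4-cyanophenyl ring carries the step, which a methanesulfonyl or an unsubstituted phenylsulfonyl group on this nitrogen would help to separate. Also open, as far as these compounds go, is whether the step would hold with a 4-morpholinophenyl group in place of the 4-(1H-imidazol-1-yl)phenyl group.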